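This account rests on a few compounds, and the source may have more. Where it says the series, first, only, none or still open, it means among the compounds named here.

Compound 1 `Nc1nc(O)c2c(n1)n(C1OC(CO)[C@@H](O)[C@H]1O)c(=O)n2Cc1ccc(Cl)cc1` and compound 2 `Nc1nc(O)c2c(n1)n(C1OC(CO)[C@@H](O)[C@H]1O)c(=O)n2Cc1ccc(OCc2ccccc2)cc1` share one core and differ only in one group on the aromatic ring that hangs from the core. In a functional assay on the whole organism (B cells) with Mus musculus as the target (on this read-out lower numbers stand for smaller maximal responses and higher numbers for larger maximal responses), compound 1 gives 15%, and compound 2 gives 5%. The step of a number 10 percentage points lower from compound 1 to compound 2 (within the scatter) lies within the scatter, so on the numbers shown compound 1 cannot be told apart from compound 2; both responses are small.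

Compound 3 `CCCCn1c(=O)n(C2OC(CO)[C@@H](O)[C@H]2O)c2nc(N)nc(O)c21` changes compound 1 in a different way: propyl in place of 4-chlorophenyl on a saturated chain carbon bound to an aromatic nitrogen. Among the compounds with values here, the only measured step swaps one substituent on that aromatic ring for another and leaves the ring in place, so it does not directly speak to removing the ring and keeping a short chain instead. What the two measured compounds do show is that the response stayed small in both cases, and there is nothing here that points to a move upward or downward beyond the scatter.

Compound 3 is therefore expected to give about 15%, in a range from 3% to 40%. The expected step is no change at the digits printed from compound 1 to compound 3 (within the scatter), none beyond the scatter.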

Compound 3, largest response reached (reported as maximal response), in percent of the reference or control that the assay uses: 86%
The estimate for compound 3 lay 71 percentage points below the measured number, and the stated range ends below it.
By their numbers in this assay, from the lowest: compounds 2 and 1 (each within the scatter of the next); then compound 3.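

Unlike the swap on the aromatic ring, which stayed within the scatter (a number 10 percentage points lower from compound 1 to compound 2 (within the scatter)), the change at this position moves the response in this assay by a wide margin: a number 71 percentage points higher from compound 1 to compound 3 (beyond the scatter). The position on a saturated chain carbon bound to an aromatic nitrogen therefore matters greatly for this read-out, and a large maximal response does not need the aromatic ring, since compound 3, with a butyl chain in place of 4-chlorobenzyl, has no ring there. Nothing shown gives a measured reason for this rise, so the result stands as an observation and not an explanation.

This single step removes the ring and the chlorine and also changes the chain, so it cannot show which of these alters the response, and a plain benzyl group without chlorine would help to separate them. It also leaves open how the response depends on chain length and chain ending, which an ethyl group, a hexyl chain or a butyl chain ending in an amine could test.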